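Cyclopentylamino to amino on the shared core

This account rests on a few compounds, and the source may have more. Where it says the series, first, only, none or still open, it means among the compounds named here.

Measured compounds:
compound 1, `CCCn1c(-c2ccccc2)nc2c(NC3CCCC3)ncnc21`: 3430 nM
compound 2, `Cn1c(-c2ccccc2)nc2c(NC3CCCC3)ncnc21`: 8510 nM

Going by the values given here, in a functional assay on CHO cells for antagonist activity at adenosine receptor A2b (Homo sapiens), read by 33P incorporation, with a stated time of 20 min (a lower number here means a stronger inhibitor, a higher number a weaker inhibitor), compound 1 gives the lower of the two numbers; the only neighbour is compound 2, and a 2.5-fold higher number from compound 1 to compound 2 (0.39 log units; beyond the scatter). That single step concerns the chain on the aromatic nitrogen, not the amine.

Compound 3, `CCCn1c(-c2ccccc2)nc2c(N)ncnc21`, has not been measured in this assay. It differs from compound 1 by hydrogen in place of cyclopentyl on a nitrogen on an aromatic ring. Among the compounds with values here, no measured pair here changes the amine substituent, so the step from compound 1 to compound 2 gives no direct guide to the size or direction of this change; it only shows that a modest trimming elsewhere on the core already cost something.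

Within the data shown here, with no direct precedent, the expectation is set on general grounds: in this assay compound 3 is expected to give a weaker result than compound 1, estimated as a 5.8-fold higher number from compound 1 to compound 3 (0.77 log units; beyond the scatter). Compound 3 is thus estimated at 20000 nM, with a range of 6000 nM to 70000 nM.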

Compound 3, inhibition constant: 1040 nM
For compound 3 the middle estimate is 19-fold (1.28 log units) above the measured one; the measured number lies below the stated range.
By their numbers in this assay, from the lowest: compound 3; then compound 1; then compound 2.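

In this assay, going by these compounds alone, replacing cyclopentyl with hydrogen on the nitrogen on an aromatic ring gives a 3.3-fold lower number from compound 1 to compound 3 (0.52 log units; beyond the scatter), the first reading at this position. The cyclopentyl group is therefore not required for the activity of compound 1, and the plain amino group does better here, with the chain on the aromatic nitrogen kept unchanged. No supporting data bear on why the number falls with this change.

Within the data shown here, with only this one pair at the amine, it remains open whether the number follows substituent size, and groups such as methylamino or cyclopropylamino would be needed to test that. Also open, on these data alone, is whether cyclopentylamino to amino gives a similar step when the chain on the aromatic nitrogen is the shorter one of compound 2.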